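The compounds below may be only part of what the source reports. "The series", "measured", "known", "first", "only" and "open" are said of these compounds alone.

Among the measured compounds shown here, in a functional assay on PC-3 cells (Homo sapiens) for inhibition, read by sulforhodamine B assay (a lower number here means a stronger inhibitor of growth, a higher number a weaker inhibitor of growth), compound 1 `Cc1ccc(CN2CCC=C(CCC(=O)NO)C2=O)cc1` gives 8100 nM, the only number available. Compound 2 `O=C(CCC1=CCCN(Cc2ccc3ccccc3c2)C1=O)NO` is entered as "not determined" (no result reported). Compound 3 `O=C(CCC1=CCCN(Cc2ccc(Br)cc2)C1=O)NO` differs from compound 1 in one place: bromo in place of methyl on an aromatic carbon, para to a large group. For the measured compounds named here, no measured pair shows the size of such a change in this assay. A slight move toward stronger growth inhibition is expected, but none beyond the scatter. The expected change is a 1.4-fold lower number from compound 1 to compound 3 (0.13 log units; within the scatter). Compound 3 is estimated at 6000 nM, with a range of 2500 nM to 14000 nM.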

Compound 3, concentration for 50% growth inhibition: 3150 nM
The estimate for compound 3 lay 1.9-fold (0.28 log units) above the measured number; the range from low to high includes it.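

In this assay, among the compounds shown here, the change from 4-methylphenyl to 4-bromophenyl gives a 2.6-fold lower number from compound 1 to compound 3 (0.41 log units; beyond the scatter), the first measured step. It shows that the growth inhibition read here responds to the group at this position, para to a large group, and that bromo in place of methyl moves the number modestly beyond the scatter. Nothing measured here bears on why it moves. Still open, going by these compounds, is how chloro, methoxy or an amine on the same aromatic carbon would compare, and whether the number follows any trend across such groups.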